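The source may report more compounds than this note shows. Statements on the series, on what has been measured and on what is new or still open speak of the compounds shown alone.

Two pairs of related compounds were tested in a functional assay on MCF7 cells (Homo sapiens) for antiproliferative activity, read by MTT assay, with a stated time of 24 h; a higher number here means a weaker inhibitor, a lower number a stronger inhibitor. Compound 1 `O=C1O/C(=C\Cn2cc(Cc3ccccc3)nn2)C(OCc2ccccc2)=C1OCc1ccccc1` carries a 4-benzyl-1H-1,2,3-triazol-1-yl group and gives 40000 nM. Compound 2 `Cc1ccc(-c2cn(C/C=C3\OC(=O)C(OCc4ccccc4)=C3OCc3ccccc3)nn2)cc1` differs from it by 4-methylphenyl in place of benzyl on an aromatic carbon. In this assay compound 2 reaches only a limit, > 100000 nM, so no exact number is known for it; it is one of the values that sit at the limit of > 100000 nM in this assay, at which 1 of the 3 values shown sits. The step of an at least 2.5-fold higher number from compound 1 to compound 2 (0.39 log units; beyond the scatter) therefore describes a weakening, though its full extent is hidden by that limit.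

Compound 3 `O=C1NC(O)(CCn2cc(Cc3ccccc3)nn2)C(OCc2ccccc2)=C1OCc1ccccc1` has a different core, and how its core differs from the core of compound 1 is not broken down here. In this assay compound 3 gives 39200 nM, a value that sits within the usual scatter of the number for compound 1, so the two cannot be told apart on this evidence.

Compound 4 `Cc1ccc(-c2cn(CCC3(O)NC(=O)C(OCc4ccccc4)=C3OCc3ccccc3)nn2)cc1` has not yet been measured. Its relation to compound 3 is 4-methylphenyl in place of benzyl on an aromatic carbon, the same change that was made from compound 1 to compound 2, at the same place in the molecule. Since compound 3 starts close to where compound 1 started, the expected step of a 2.6-fold higher number from compound 3 to compound 4 (0.41 log units; beyond the scatter) for compound 4 is estimated from the earlier step of an at least 2.5-fold higher number from compound 1 to compound 2 (0.39 log units; beyond the scatter). In this assay compound 4 is expected to give about 100000 nM, likely between 55000 nM and 250000 nM, and it may well be reported only as a limit.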

Compound 4, half-maximal inhibitory concentration: 24000 nM
For compound 4 the middle estimate is 4.2-fold (0.62 log units) above the measured one, and the stated range ends above it.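

In this assay, the exchange of 4-benzyl-1H-1,2,3-triazol-1-yl for 4-(4-methylphenyl)-1H-1,2,3-triazol-1-yl does not behave alike on the two cores, and the gap between its two steps is larger than chance scatter would readily explain: the same change on two cores in this assay, an at least 2.5-fold higher number (0.39 log units; beyond the scatter) from compound 1 to compound 2 and a 1.6-fold lower number (0.21 log units; within the scatter) from compound 3 to compound 4, at least 4.0-fold (0.61 log units) apart, beyond the scatter of two such steps

On the second core the step is a 1.6-fold lower number from compound 3 to compound 4 (0.21 log units; within the scatter), so the weakening seen on the first core does not repeat there, but no gain can be claimed either, and with a single pair on each core the result does not show which feature of the cores sets the two steps apart. Compound 2 reaches only a limit, > 100000 nM, so the first step has a known minimum but no known full size: the limit of > 100000 nM in this assay, at which 1 of the 4 values shown sits.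

The compounds shown carry only benzyl or 4-methylphenyl at this place on the triazole, so it remains open how a plain phenyl, a 4-methoxyphenyl or a longer alkyl chain would behave on each core. On these data alone, it also remains open whether the two cores would part in the same way for such groups, or whether this one difference is particular to the pair tested.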